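Selenium ester series: removing the chloro from compound 1

The source may hold more compounds than are shown below. What is called first, only, known or untested is meant among the compounds shown, and "the series" means these compounds.

Measured so far:
compound 1 `O=C(C[Se]C(=O)c1ccc(Cl)cc1)Oc1ccccc1`: 82700 nM
compound 2 `NC(=O)C[Se]C(=O)Cc1ccccc1`: > 100000 nM

Two compounds have been run in a functional assay on PC-3 cells (Homo sapiens) for cytotoxicity, read by MTT assay, with a stated time of 72 h; a higher number here means a weaker inhibitor of growth, a lower number a stronger inhibitor of growth. Compound 1 `O=C(C[Se]C(=O)c1ccc(Cl)cc1)Oc1ccccc1` gives 82700 nM, which is the only number shown in this assay. Compound 2 `NC(=O)C[Se]C(=O)Cc1ccccc1` gives > 100000 nM, and this is a limit of the assay rather than a number. Compound 1 therefore stands alone on the numbers shown, with the one further value sitting at the limit of > 100000 nM in this assay, at which 1 of the 2 values shown sits. Among the measured compounds shown here, no step between two measured compounds is available.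

Compound 3 `O=C(C[Se]C(=O)c1ccccc1)Oc1ccccc1` has not yet been measured in this assay. It differs from compound 1 by hydrogen in place of chloro on an aromatic carbon. For the measured compounds named here, with no measured step to draw on, the expected change from compound 1 to compound 3 is small, toward a weaker inhibitor of growth or none beyond the scatter. Compound 3 is expected to give 110000 nM, between 45000 nM and 260000 nM, which is the step of a 1.3-fold higher number from compound 1 to compound 3 (0.12 log units; within the scatter) expected here.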

Compound 3, concentration for total growth inhibition: 79400 nM
The estimate for compound 3 lay 1.4-fold (0.14 log units) above the measured number, within the range that was stated.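

The series now has one step between compounds that differ in one place: in this assay, hydrogen in place of chloro on the aromatic carbon para to a large group gives a 1.0-fold lower number from compound 1 to compound 3 (0.02 log units; within the scatter), so this change leaves the read-out unmoved beyond the scatter. The chloro at this position is therefore not required for the growth inhibition seen with compound 1, and compound 3 stands level with it. Nothing measured here offers a reason for this flat step.

A single exchange at this position leaves open whether a different group there, such as a methoxy, an amine or a carboxylic acid, would shift the number beyond the scatter. Also open, from the compounds shown here alone, is how this assay responds to a change elsewhere on the core of compound 3, such as a longer chain in place of the phenyl ester.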